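The source may hold more compounds than are shown below. What is called first, only, known or untested is meant among the compounds shown, and "the series" means these compounds.

In a functional assay on the whole organism for inhibition, with Mus musculus as the target, in the writhing test, at a dose of 6.25 mg/kg (on this read-out lower numbers stand for a weaker effect and higher numbers for a stronger effect at the one dose given), compound 1 `Cc1ccccc1-c1noc(CN2C(=O)c3ccccc3C2=O)n1` gives 80.5%. Compound 2 `Cc1cccc(-c2noc(CN3C(=O)c4ccccc4C3=O)n2)c1` gives 79.2% in this assay, and the shift a number 1.3 percentage points lower from compound 1 to compound 2 (within the scatter) leaves the two within the scatter of each other, so compound 2 cannot be set apart from compound 1 on these numbers. Compound 3 `Cc1ccc(-c2noc(CN3C(=O)c4ccccc4C3=O)n2)cc1` differs from compound 2 by 4-methylphenyl in place of 3-methylphenyl on an aromatic carbon. Going by the values given here, the only measured step of a comparable kind, a number 1.3 percentage points lower from compound 1 to compound 2 (within the scatter), lay within the scatter, so the step of a number 0.2 percentage points lower from compound 2 to compound 3 (within the scatter) is expected to stay within the scatter as well. Compound 3 is estimated at 79%, with a range of 68% to 90%.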

Compound 3, a percentage reported as inhibition, in the whole organism at one dose (the size of the read-out at that dose, not a potency): 62.4%
Beside the measured number, compound 3's estimate is 16.6 percentage points above it; the measured number lies below the stated range.
By their numbers in this assay, from the lowest: compound 3; then compounds 2 and 1 (each within the scatter of the next).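

In this assay the place of the methyl group on the phenyl ring matters: 4-methylphenyl gives a number 16.8 percentage points lower from compound 2 to compound 3 (beyond the scatter) and also a number 18.1 percentage points lower from compound 1 to compound 3 (beyond the scatter) while 2-methylphenyl and 3-methylphenyl remain within the scatter of each other. Compound 3 thus separates from compound 1 and compound 2 with the same atoms joined differently. Nothing measured here accounts for this difference. Still open, from the compounds shown here alone, is whether unsubstituted phenyl, 4-methoxyphenyl or a phenyl carrying an amine or a carboxylic acid would track compound 3 or the other two. The gap is also known at only one dose.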